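Fluoro for Methyl on the Aryl Ring of Compound 1

A few compounds are considered here, and "the series" means these few. Any claim that something is new, unique, unknown or untested is made for them only; others in the source may bear on it.

Going by the values given here, compound 1 `COc1ncc(-c2ccc3c(c2)N(c2ccc(C)cc2)C(=O)CO3)cc1NS(=O)(=O)c1ccc(F)cc1` is the only compound in this set with a numerical result: in a functional assay on A-375 cells (Homo sapiens) for antiproliferative activity, read by MTT assay, with a stated time of 72 h (a higher number here means a weaker inhibitor, a lower number a stronger inhibitor), compound 1 gives 12900 nM. Compound 2 `COc1ccc(N2C(=O)COc3ccc(-c4cnc5ccccc5c4)cc32)cc1` is a different case: in this assay compound 2 reaches only > 40000 nM, which is a limit of the assay and not a number, so that (the limit of > 40000 nM in this assay, at which 1 of the 2 values shown sits). Among the compounds with values here, compound 2 differs from compound 1 in more than one place, and no step between two measured compounds can be read from the pair.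

Compound 3 `COc1ncc(-c2ccc3c(c2)N(c2ccc(F)cc2)C(=O)CO3)cc1NS(=O)(=O)c1ccc(F)cc1` differs from compound 1 in a single place: fluoro in place of methyl on an aromatic carbon. Read one bond further out, the change is 4-methylphenyl to 4-fluorophenyl. Within the data shown here, with no measured step of this kind to draw on, the writer expects the step of a 1.1-fold lower number from compound 1 to compound 3 (0.03 log units; within the scatter) to be small, within the usual scatter, in either direction. Compound 3 is therefore expected to give about 12000 nM in this assay, with a likely range from 5000 nM to 30000 nM.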

Compound 3, half-maximal inhibitory concentration: > 40000 nM
Compound 3: a limit, no number; the forecaster's own chance of this, stated with the estimate: 15%; middle value at least 3.3-fold (0.52 log units) away from the limit.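

On the core of compound 1, the aromatic carbon para to a large group proves sensitive to a change of a single heavy atom: in this assay, replacing 4-methylphenyl with 4-fluorophenyl gives an at least 3.1-fold higher number from compound 1 to compound 3 (0.49 log units; beyond the scatter). The value of compound 3, > 40000 nM, is a limit of the assay and not a number, so the step has a lower bound but no measured size. Compound 3 now stands with compound 2, leaving compound 1 as the only compound with a numerical result: the limit of > 40000 nM in this assay, at which 2 of the 3 values shown sit.

The compounds shown leave open whether hydrogen, chloro, ethyl, methoxy or an amine on this carbon would keep, lose or improve the activity of compound 1. They also leave open whether fluoro in place of methyl would give a similar step on another core, as this change is read only once.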